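Chlorophenyl for Ethoxyphenyl: an Expected Modest Shift

A few compounds are considered here, and "the series" means these few. Any claim that something is new, unique, unknown or untested is made for them only; others in the source may bear on it.

Among the compounds with values here, in an assay on liver for binding affinity to Alpha-1D adrenergic receptor (Homo sapiens), using microsomes (on this read-out lower numbers stand for stronger inhibition and higher numbers for weaker inhibition), compound 3 `CCOc1ccccc1N1CCN(CCCNC(=O)N2C(=O)NC(C)=C(C(=O)OC)C2c2ccc(F)c(F)c2)CC1` gives 14 nM, the lowest of the three numbers known. Compound 1 `COC(=O)C1=C(C)NC(=O)N(C(=O)NCCCN2CCN(c3ccccc3O)CC2)C1c1ccc(F)c(F)c1` gives 31 nM and compound 2 `COC(=O)C1=C(C)NC(=O)N(C(=O)NCCCN2CCN(c3ccc(Cl)cc3)CC2)C1c1ccc(F)c(F)c1` gives 52 nM. Compound 4 `COC(=O)C1=C(C)NC(=O)N(C(=O)NCCCN2CCN(c3cccc(Cl)c3)CC2)C1c1ccc(F)c(F)c1` differs from compound 3 by 3-chlorophenyl in place of 2-ethoxyphenyl on an amine nitrogen in a ring. Within the data shown here, two measured steps bear on this change. a 3.7-fold lower number from compound 2 to compound 3 (0.57 log units; beyond the scatter) shows that exchanging a chlorophenyl for the 2-ethoxyphenyl lowered the number modestly, while a 1.7-fold higher number from compound 1 to compound 2 (0.22 log units; within the scatter) shows that a hydroxyphenyl and a chlorophenyl gave numbers within the scatter of each other. Returning from the 2-ethoxyphenyl to a chlorophenyl is therefore expected to raise the number by a modest step in this assay: a 2.9-fold higher number from compound 3 to compound 4 (0.46 log units; beyond the scatter). Compound 4 is estimated at 40 nM, with a likely range from 18 nM to 90 nM.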

Compound 4, inhibition constant: 37 nM
The estimate for compound 4 lay 1.1-fold (0.03 log units) above the measured number; the range from low to high includes it.
By their numbers in this assay, from the lowest: compound 3; then compounds 1, 4 and 2 (each within the scatter of the next).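

In this assay, the 2-ethoxyphenyl of compound 3 now also stands apart from a second chlorophenyl (a 2.6-fold higher number from compound 3 to compound 4 (0.42 log units; beyond the scatter)). Where the chlorine sits on the phenyl ring gives no readable difference (a 1.4-fold lower number from compound 2 to compound 4 (0.15 log units; within the scatter)), and the 3-chlorophenyl cannot be told apart from the 2-hydroxyphenyl either (a 1.2-fold higher number from compound 1 to compound 4 (0.08 log units; within the scatter)). No measured evidence here explains these numbers. The compounds shown leave open how a phenyl ring carrying an amine or a carboxylic acid would read at this place. They also leave open whether a longer chain on the oxygen of the 2-ethoxyphenyl would keep the lower number.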